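The compounds below may be only part of what the source reports. "The series", "measured", "known", "first", "only" and "open" are said of these compounds alone.

Measured compounds:
compound 1 `COc1cc(-c2cc(/C=C/C(=O)c3ccc(N)cc3)[nH]n2)cc(OC)c1OC`: 85%
compound 2 `COc1cc(C(=O)/C=C/c2cc(-c3cc(OC)c(OC)c(OC)c3)n[nH]2)cc(OC)c1OC`: 102%

In a functional assay on BT-549 cells (Homo sapiens) for cytotoxicity, read by sulforhodamine B assay, with a stated time of 48 h, tested at 0.01 uM (a higher number here means a weaker effect of the compound at the concentration tested, a lower number a stronger effect), compound 1 gives 85%, the lowest of the two numbers. The nearest neighbour is compound 2, which gives 102% in this assay, a number higher than that of compound 1 and beyond the scatter. Among the compounds with values here, no step between two measured compounds that differ in one place is available, so nothing itself sizes the change from compound 1 to compound 3 `COc1cc(-c2cc(/C=C/C(=O)c3ccc(F)c(F)c3)[nH]n2)cc(OC)c1OC`: 3,4-difluorophenyl in place of 4-aminophenyl on a carbonyl carbon. The step of a number 7 percentage points higher from compound 1 to compound 3 (within the scatter) is expected to be small, towards a higher number, and may not exceed the scatter. Compound 3 is estimated at 92%, with a range from 72% to 108%.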

Compound 3, a percentage reported as activity, at one concentration (the size of the read-out at that concentration, not a potency): 101%
Compound 3: the middle estimate sits 9 percentage points below what was measured; low and high end bracket the measured number.
By their numbers in this assay, from the lowest: compound 1; then compounds 3 and 2 (each within the scatter of the next).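

In this assay, within the data shown here, 3,4-difluorophenyl in place of 4-aminophenyl on the carbonyl carbon gives the first step that can be read at this position: a number 16 percentage points higher from compound 1 to compound 3 (beyond the scatter). The group on this carbonyl carbon can therefore shift the read-out by more than the scatter, and of this pair, the 4-aminophenyl compound holds the lower number. Nothing available explains the step.

The compounds shown do not separate the loss of the amine from the gain of the two fluorines. On these data alone, how a plain phenyl or a 4-hydroxyphenyl group would read at this position remains open.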